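Cytotoxicity limits: cyclopropyl in place of vinyl on the ester

A few compounds are considered here, and "the series" means these few. Any claim that something is new, unique, unknown or untested is made for them only; others in the source may bear on it.

Compound 1 `COc1ccc(/C=C/C(=O)c2ccc(OC)c3c2OC(C)(C)C=C3)cc1O`, compound 2 `C#CCOc1cc(/C=C/C(=O)c2ccc(OC)c3c2OC(C)(C)C=C3)ccc1OC` and compound 3 `C=CC(=O)Oc1cc(/C=C/C(=O)c2ccc(OC)c3c2OC(C)(C)C=C3)ccc1OC` differ only in the group on an oxygen on an aromatic ring. In an ADME assay on L02 cells (Homo sapiens) for cytotoxicity, read by MTT assay (a higher number here means a weaker inhibitor, a lower number a stronger inhibitor), compound 1 gives > 10000 nM, which is a limit. In this assay compound 2 gives > 10000 nM, also a limit. In this assay compound 3 gives > 10000 nM, again a limit and not a number. The three compounds share (the limit of > 10000 nM in this assay, at which 3 of the 3 values shown sit).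

Compound 4 `COc1ccc(/C=C/C(=O)c2ccc(OC)c3c2OC(C)(C)C=C3)cc1OC(=O)C1CC1` keeps the scaffold of compound 3 and changes one group: cyclopropyl in place of vinyl on a carbonyl carbon.

The measured steps on this oxygen give no size: a step that the two limits leave unreadable from compound 1 to compound 2, a step that the two limits leave unreadable from compound 1 to compound 3 and a step that the two limits leave unreadable from compound 2 to compound 3. The closest of these is the last, and it also changes the group on this oxygen. For the measured compounds named here, no step of known size or direction therefore exists to carry over, and the expectation is that compound 4 also stays at the limit, with a step that the limit leaves unreadable from compound 3 to compound 4 expected. The estimate for compound 4 is 20000 nM, with an expected range of 10000 nM to 50000 nM.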

Compound 4, half-maximal inhibitory concentration: > 10000 nM
Compound 4 ended at the assay's limit; the forecaster's own chance of this, stated with the estimate: 85%; the middle value lies beyond the limit too.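

In this assay compound 4 gives > 10000 nM, a limit and not a number, so its steps from compound 1, compound 2 and compound 3 cannot be read. The compounds shown leave open whether any group on this oxygen changes the read-out at all, as every value sits at one limit: the limit of > 10000 nM in this assay, at which 4 of the 4 values shown sit.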